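A few compounds are considered here, and "the series" means these few. Any claim that something is new, unique, unknown or untested is made for them only; others in the source may bear on it.

Measured compounds:
compound 1, `CC(C)C(=O)NCCCc1cccc2c1C[C@@H](CCCCc1ccccc1)O2`, 40 nM
compound 2, `CCC(=O)NC[C@@H]1C[C@H]1c1cccc2c1C[C@@H](CCCCc1ccccc1)O2`, 2 nM

In an assay on NIH3T3 cells for binding affinity to melatonin receptor type 1B (Homo sapiens) (on this read-out higher numbers stand for weaker inhibition and lower numbers for stronger inhibition), compound 2 stands lowest of the two numbers; its nearest neighbour is compound 1, a step of a 20-fold lower number from compound 1 to compound 2 (1.30 log units; beyond the scatter). Compound 3, `CCCC(=O)NCCCc1cccc2c1C[C@@H](CCCCc1ccccc1)O2`, differs from compound 2 by 3-((propylcarbonyl)amino)propyl in place of 2-((propanoylamino)methyl)cyclopropyl on an aromatic carbon. Within the data shown here, the one measured step that bears on this change, a 20-fold lower number from compound 1 to compound 2 (1.30 log units; beyond the scatter), runs the other way, exchanging a chain for the three-membered ring; compound 3 returns to a chain, with only the acyl part differing from compound 1. A step of roughly that size upward is therefore expected, an 18-fold higher number from compound 2 to compound 3 (1.24 log units; beyond the scatter), and compound 3 is estimated at 35 nM, within 10 nM to 120 nM.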

Compound 3, inhibition constant: 30 nM
Compound 3: the middle estimate sits 1.2-fold (0.07 log units) above what was measured, within the range that was stated.
By their numbers in this assay, from the lowest: compound 2; then compounds 3 and 1 (each within the scatter of the next).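

In this assay, the step of a 15-fold higher number from compound 2 to compound 3 (1.18 log units; beyond the scatter) shows that the low number of compound 2 is not kept when 2-((propanoylamino)methyl)cyclopropyl gives way to the ring-free 3-((propylcarbonyl)amino)propyl, although both groups hold the same count of heavy atoms. With the propyl chain in place, exchanging isopropyl for propyl on the carbonyl carbon changes little, with a 1.3-fold lower number from compound 1 to compound 3 (0.12 log units; within the scatter). The data give no explanation for the difference between the ring and the chain. Still open, going by these compounds, is whether a cyclobutyl ring in place of the cyclopropyl, or an acetyl group in place of the propanoyl, would keep the low number of compound 2.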